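Piperazin-1-yl in Place of Hydroxyethylamino: Expected Cytotoxicity

The source may report more compounds than this note shows. Statements on the series, on what has been measured and on what is new or still open speak of the compounds shown alone.

Measured compounds:
compound 1, `Cc1cc(NC(C)C)nc(SCc2nc3ccccc3[nH]2)n1` — in a functional assay on MCF7 cells (Homo sapiens) for cytotoxicity, read by MTT assay, with a stated time of 72 h (on this read-out higher numbers stand for weaker inhibition and lower numbers for stronger inhibition), compound 1 gives > 100000 nM, a limit of the assay.
compound 2, `Cc1cc(Nc2ccc(Cl)cc2)nc(SCc2nc3ccccc3[nH]2)n1` — in this assay compound 2 gives 33600 nM.
compound 3, `Cc1cc(NCCO)nc(SCc2nc3ccccc3[nH]2)n1` — in this assay compound 3 gives > 100000 nM, again a limit of the assay.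

Compound 3 thus stands at the weak end, where the limit of > 100000 nM in this assay, at which 2 of the 3 values shown sit, gathers two of the three values. Compound 4, `Cc1cc(N2CCNCC2)nc(SCc2nc3ccccc3[nH]2)n1`, differs from compound 3 by piperazin-1-yl in place of (2-hydroxyethyl)amino on an aromatic carbon. Of the measured steps, an at least 2.9-fold lower number from compound 1 to compound 2 (0.47 log units; beyond the scatter) and an at least 2.9-fold higher number from compound 2 to compound 3 (0.47 log units; beyond the scatter) show that only 4-chlorophenyl on that nitrogen yields a readable number, while a step that the two limits leave unreadable from compound 1 to compound 3 leaves the exchange of small groups unresolved. Piperazin-1-yl, carrying no aromatic ring, is closer in kind to 2-hydroxyethyl than to 4-chlorophenyl, so no step beyond the scatter is expected, a step that the limit leaves unreadable from compound 3 to compound 4. Compound 4 is therefore estimated at 120000 nM, between 40000 nM and 400000 nM, most likely reported only as a limit.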

Compound 4, half-maximal inhibitory concentration: > 100000 nM
Compound 4 was reported as a limit; the forecaster's own chance of this, stated with the estimate: 70%; the middle value is on the limit's open side.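

Piperazin-1-yl shows that a six-membered non-aromatic ring on this aromatic carbon does not bring a readable number in this assay: compound 4 gives > 100000 nM, a limit of the assay. Going by these compounds alone, the one readable comparison is an at least 2.9-fold higher number from compound 2 to compound 4 (0.47 log units; beyond the scatter), while the steps among the compounds at the limit cannot be read. The values now gather at one end: the limit of > 100000 nM in this assay, at which 3 of the 4 values shown sit.

On these data alone, whether a morpholin-4-yl or benzylamino group here would give a readable number stays open. Also open, as far as these compounds go, is whether that number needs the chlorine, which a plain phenylamino group would test.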